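A few compounds are considered here, and "the series" means these few. Any claim that something is new, unique, unknown or untested is made for them only; others in the source may bear on it.

Measured so far:
Compound 1 `O=C(CCCCC1CCSS1)Nc1ccc(OC(F)(F)F)cc1` gives 5.53%
Compound 2 `O=C(CCCCC1CCSS1)Nc1ccc(Cl)cn1` gives "not active" (no number reported)
Compound 3 `O=C(CCCCC(S)CCS)Nc1ccc(Cl)cc1` gives 1.04%

In a functional assay on HO8910 cells (Homo sapiens) for inhibition, read by MTT assay, with a stated time of 24 h, tested at 0.1 ug/mL (a higher number here means more inhibition of growth at the concentration tested, a lower number less inhibition of growth), compound 3 stands at 1.04% and compound 1 at 5.53% lies within the usual scatter of it. Compound 2 adds no number to this comparison, since it was reported only as "not active" (no number reported) and nothing more. Within the data shown here, no two measured compounds differ in just one place, so the data do not show the size of any single change.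

Compound 4 `O=C(CCCCC(S)CCS)Nc1ccc([N+](=O)[O-])cc1` departs from compound 3 at one place, with nitro in place of chloro on an aromatic carbon, para to a large group (nitro in place of chloro on an aromatic carbon). Compound 1 at 5.53% and compound 3 at 1.04% differ in more than one place and still remain within the scatter of each other, so no step beyond the scatter is expected here. The estimated step of a number 2 percentage points higher from compound 3 to compound 4 (within the scatter) stays within the scatter, with only a slight lean upward. A report without a number, as happened with compound 2, also remains possible. For compound 4 the expected value is 3% within an estimated range of 0% to 12% in this measurement.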

Compound 4, percent growth inhibition at one concentration: "not active" (no number reported)
No number was reported for compound 4; the estimate stays without a comparison.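

In this assay, among these compounds, compound 4 is reported as "not active" (no number reported), so no step from compound 3, at 1.04%, can be read for nitro in place of chloro. No measured property bears on this result. The compounds shown leave open how far this change moves growth inhibition in the series.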